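Removing a Fluorine: From Compound 1 to Compound 4

The source may hold more compounds than are shown below. What is called first, only, known or untested is meant among the compounds shown, and "the series" means these compounds.

In an assay on cells for inhibition of Voltage-dependent T-type calcium channel subunit alpha-1G (Homo sapiens), read by patch clamp, tested at 10 uM (a lower number here means less inhibition, a higher number more inhibition at the concentration tested (going by the name of the read-out)), compound 1 `CN(C)CCCCCSC1=Nc2ccccc2C(CC(=O)NCc2ccccc2)N1c1ccc(-c2ccc(F)cc2)cc1` gives 97.6%.
Compound 2 `O=C(CC1c2ccccc2N=C(SCCCCCN2CCCC2)N1c1ccccc1)NCc1ccc(F)cc1` gives 60.1% in this assay.
Compound 3 `CN(C)CCCCCSC1=Nc2ccccc2C(CC(=O)NCc2ccc(F)cc2)N1c1ccc(-c2ccc(F)cc2)cc1` gives 96.2% in this assay.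

Compound 1 thus has the highest of the three numbers, with compound 3 within the scatter of it and compound 2 well beyond. Compound 4 `CN(C)CCCCCSC1=Nc2ccccc2C(CC(=O)NCc2ccccc2)N1c1ccc(-c2ccccc2)cc1` differs from compound 1 by hydrogen in place of fluoro on an aromatic carbon. Going by the values given here, the one measured step that bears on this is a number 1.4 percentage points lower from compound 1 to compound 3 (within the scatter), the same kind of swap, run the other way, at another aromatic carbon, and it stayed within the scatter. The expectation is therefore no step beyond the scatter in this assay, written as a number 2.6 percentage points lower from compound 1 to compound 4 (within the scatter). Compound 4 is estimated at 95%, between 84% and 100%.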

Compound 4, a percentage reported as inhibition, at one concentration (the size of the read-out at that concentration, not a potency): 76.2%
Compound 4: middle estimate off by 18.8 percentage points, on the high side, outside the stated range (below it).
By their numbers in this assay, from the lowest: compound 2; then compound 4; then compounds 3 and 1 (each within the scatter of the next).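

In this assay, replacing 4-fluorophenyl with phenyl gives a number 21.4 percentage points lower from compound 1 to compound 4 (beyond the scatter), so the single fluoro at this place matters. The same kind of swap at another aromatic carbon, a number 1.4 percentage points lower from compound 1 to compound 3 (within the scatter), did not have that effect, so in these compounds the outcome depends on where the change is made. No measurement here explains the difference.

Going by these compounds, it remains open whether a chloro, methyl or methoxy group at this place would keep the number near that of compound 1, or whether only fluoro does.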